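Toward a nitrophenyl on the sulfonamide of compound 3

The source may hold more compounds than are shown below. What is called first, only, known or untested is meant among the compounds shown, and "the series" means these compounds.

Of the compounds shown here, three sharing one core have been tested in a functional assay on HeLa cells (Homo sapiens) for inhibition, read by MTT assay, with a stated time of 72 h; on this read-out lower numbers stand for stronger inhibition and higher numbers for weaker inhibition. Compound 1 `O=c1cc(Cn2cc(CNS(=O)(=O)c3ccc(Cl)cc3)nn2)c2ccc(O)cc2o1` gives 58500 nM. Compound 2 `O=c1cc(Cn2cc(CNS(=O)(=O)c3ccc(F)cc3)nn2)c2ccc(O)cc2o1` reaches only the assay limit of > 100000 nM. Compound 3 `O=c1cc(Cn2cc(CNS(=O)(=O)c3ccc(F)cc3Cl)nn2)c2ccc(O)cc2o1` gives 74900 nM, the larger of the two numbers shown, with compound 1 sitting within the scatter of it. The steps of an at least 1.7-fold higher number from compound 1 to compound 2 (0.23 log units; that floor lies within the scatter), a 1.3-fold higher number from compound 1 to compound 3 (0.11 log units; within the scatter) and an at least 1.3-fold lower number from compound 2 to compound 3 (0.12 log units; that floor lies within the scatter) all lie inside the scatter or at its floor. Compound 4 `O=c1cc(Cn2cc(CNS(=O)(=O)c3ccc([N+](=O)[O-])cc3)nn2)c2ccc(O)cc2o1` differs from compound 3 by 4-nitrophenyl in place of 2-chloro-4-fluorophenyl on a sulfonyl sulfur. The steps bearing on this aryl exchange are small, so in this assay the expected step is a 1.0-fold higher number from compound 3 to compound 4 (0.00 log units; within the scatter), none beyond the scatter. Compound 4 is expected to give 75000 nM, with a range from 30000 nM to 150000 nM.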

Compound 4, half-maximal inhibitory concentration: > 100000 nM
Compound 4: only a limit was reported; the forecaster's own chance of this, stated with the estimate: 35%; middle value at least 1.3-fold (0.12 log units) from the limit.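

In this assay, the change to 4-nitrophenyl on the sulfonyl sulfur gives an at least 1.3-fold higher number from compound 3 to compound 4 (0.12 log units; that floor lies within the scatter) and an at least 1.7-fold higher number from compound 1 to compound 4 (0.23 log units; that floor lies within the scatter), so neither step shows a change beyond the scatter. Among the four compounds, only the aryl groups carrying chloro, in compound 1 and compound 3, give a number rather than a limit. Compound 4 now shares a limit with compound 2, and the step between them cannot be read: the limit of > 100000 nM in this assay, at which 2 of the 4 values shown sit.

From the compounds shown here alone, whether an amine or a carboxylic acid in place of the nitro would give a readable number remains open.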